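The compounds below may be only part of what the source reports. "The series", "measured", "known", "first", "only" and "open" are said of these compounds alone.

Working notes on the triazole-thiol series.

Three compounds share the core of compound 1, whose structure is `CC(C)n1c(S)nnc1CSc1nnc(-c2ccccc2)n1-c1ccccc1`. Compound 1 has no numerical result in a functional assay on HT-29 cells (Homo sapiens) for inhibition, read by MTT assay, with a stated time of 48 h; on this read-out higher numbers stand for weaker inhibition and lower numbers for stronger inhibition; the entry for compound 1 reads "not determined" (no result reported). For the measured compounds named here, compound 2, with the structure `COc1ccc(-n2c(S)nnc2CSc2nnc(-c3ccccc3)n2-c2ccccc2)cc1`, is the only member with a number: in this assay compound 2 gives 27700 nM. Going by the values given here, as the single quantified value, compound 2 is the sole reference point; no step between measured compounds can be read from the two entries, and nothing can be said about order.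

Compound 3, with the structure `Fc1ccc(-n2c(S)nnc2CSc2nnc(-c3ccccc3)n2-c2ccccc2)cc1`, is not yet measured. It differs from compound 2 by fluoro in place of methoxy on an aromatic carbon. Among the compounds with values here, no measured pair in this set shows what this change does on this core, so the expectation rests on compound 2 alone. The step from compound 2 to compound 3 is expected to stay within the usual scatter, with no clear direction, giving an estimated 1.1-fold higher number from compound 2 to compound 3 (0.03 log units; within the scatter). Compound 3 is therefore expected to give about 30000 nM in this assay, with a plausible range from 10000 nM to 90000 nM.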

Compound 3, half-maximal inhibitory concentration: 16700 nM
For compound 3 the middle estimate is 1.8-fold (0.25 log units) above the measured one; low and high end bracket the measured number.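

In this assay the exchange of methoxy for fluoro gives a 1.7-fold lower number from compound 2 to compound 3 (0.22 log units; within the scatter), so the 4-methoxyphenyl and 4-fluorophenyl compounds cannot be told apart on this read-out. This first measured pair shows that, on the shared core, a group of 2 heavy atoms with a hydrogen-bond acceptor can give way at this position to a group of 1 heavy atom without one, and the step stays within the usual scatter. No measured evidence on either group bears on this result.

One pair at one position leaves open whether a group of another kind on this aromatic ring, such as an amine, a carboxylic acid or a longer alkoxy chain, would give a step beyond the scatter. For the compounds shown here, with compound 1 at "not determined" (no result reported) no step to it can be read, and what a change to the phenyl groups elsewhere on the shared core would do also stays open.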